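The source may report more compounds than this note shows. Statements on the series, on what has been measured and on what is new or still open speak of the compounds shown alone.

In an ADME assay on a cell-free system (plasma, Mus musculus) for protein binding, compound 1 `CNc1nccc(N2CC[C@H](NC(=O)Nc3cccc(C#N)c3)C2)n1` with its 3-cyanophenyl group gives 91.5% and compound 2 `CNc1nccc(N2CC[C@H](NC(=O)Nc3ccc(OC)cc3)C2)n1` with its 4-methoxyphenyl group gives 82.1% while compound 3 `CNc1nccc(N2CC[C@H](NC(=O)Nc3ccc(C)c(Cl)c3)C2)n1` with its 3-chloro-4-methylphenyl group gives 98.6% on the same scale. Compound 2 therefore holds the highest unbound fraction of the three. The record shows a 2.1-fold higher unbound fraction from compound 1 to compound 2 (0.32 log units; beyond the scatter) as a modest step and a 13-fold lower unbound fraction from compound 2 to compound 3 (1.11 log units; beyond the scatter) as a large one, and between the other two it shows a 6.1-fold lower unbound fraction from compound 1 to compound 3 (0.78 log units; beyond the scatter) as another modest step.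

The next compound is compound 4 `CNc1nccc(N2CC[C@H](NC(=O)Nc3ccc(OC(F)F)cc3)C2)n1` and it departs from compound 2 in one group: difluoromethyl in place of methyl on an oxygen on an aromatic ring so that difluoromethyl stands in place of methyl on an oxygen on an aromatic ring. For the measured compounds named here, no measured pair shows this change itself. The measured steps each exchange a whole aryl group on an amide-type nitrogen, so they bear on it only loosely. Even so, compound 2 sits at the free end of the series, and the one departure from it, a 13-fold lower unbound fraction from compound 2 to compound 3 (1.11 log units; beyond the scatter) as the outer bound, points toward less free compound. A modest step in that direction is expected, well short of that large one. The expected step is a 1.8-fold lower unbound fraction from compound 2 to compound 4 (0.25 log units; within the scatter) as an estimate only. For compound 4 the estimated value is 90% with an expected range from 84% to 96% as the likely span.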

Compound 4, plasma protein binding: 96.8%
Beside the measured number, compound 4's estimate is 3.1-fold (0.49 log units) (unbound fraction) above it; the whole stated range lies below it.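

Every earlier step in this assay exchanged a whole aryl group on an amide-type nitrogen, whereas here the aryl group stays and only the group on an oxygen on an aromatic ring changes, with difluoromethyl in place of methyl, giving a 5.6-fold lower unbound fraction from compound 2 to compound 4 (0.75 log units; beyond the scatter). This shows that the methoxy to difluoromethoxy exchange alone moves the read-out beyond the scatter, so this position is not a silent one, and the step is printed as modest, the same class as the whole-aryl exchange a 6.1-fold lower unbound fraction from compound 1 to compound 3 (0.78 log units; beyond the scatter). Nothing measured here accounts for the shift, so its cause remains unexplained.

The compounds shown leave open whether trifluoromethoxy or ethoxy on the same oxygen would lie further in this direction, or whether a hydroxyl group there would reverse it. They also leave open whether the same methyl to difluoromethyl exchange would give a step of similar size on another aryl group, such as the 3-chloro-4-methylphenyl of compound 3, since this single pair is the only one that shows it.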